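Swapping trifluoromethyl for ethyl on the amide-bound ring

The source may hold more compounds than are shown below. What is called first, only, known or untested is meant among the compounds shown, and "the series" means these compounds.

Of the compounds shown here, three sharing one core have been tested in a functional assay on MDA-MB-231 cells (Homo sapiens) for inhibition, read by MTT assay, with a stated time of 72 h; on this read-out higher numbers stand for weaker inhibition and lower numbers for stronger inhibition. Compound 3 `O=C(CSc1nc(Nc2ccccc2)c2ccccc2n1)Nc1ccc(C(F)(F)F)cc1` gives 11100 nM, the lowest of the three numbers. Compound 1 `O=C(CSc1nc(Nc2ccccc2)c2ccccc2n1)Nc1cccc(Br)c1` gives 17500 nM, and the step of a 1.6-fold lower number from compound 1 to compound 3 (0.20 log units; within the scatter) stays within the scatter. Compound 2 `O=C(CSc1nc(Nc2ccccc2)c2ccccc2n1)Nc1cccc([N+](=O)[O-])c1` gives 33000 nM, and the step of a 3.0-fold lower number from compound 2 to compound 3 (0.47 log units; beyond the scatter) is the only one beyond the scatter; the step of a 1.9-fold higher number from compound 1 to compound 2 (0.28 log units; within the scatter) is within it.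

Compound 4 `CCc1ccc(NC(=O)CSc2nc(Nc3ccccc3)c3ccccc3n2)cc1` differs from compound 3 by ethyl in place of trifluoromethyl on an aromatic carbon. For the measured compounds named here, no measured step swaps these two groups, but all three measured steps alter the same amide-bound ring, and each is small. Compound 4 is therefore expected to stay close to compound 3, with no step beyond the scatter, so the expected step is a 1.2-fold higher number from compound 3 to compound 4 (0.07 log units; within the scatter). The estimate for compound 4 in this assay is 13000 nM, with a range from 5500 nM to 32000 nM.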

Compound 4, half-maximal inhibitory concentration: 33900 nM
Compound 4: middle estimate off by 2.6-fold (0.42 log units), on the low side, outside the stated range (above it).
By their numbers in this assay, from the lowest: compounds 3, 1, 2 and 4 (each within the scatter of the next, the first and the last beyond it).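

Swapping trifluoromethyl for ethyl at this one place on the amide-bound ring is not a neutral change in this assay: the result is a 3.1-fold higher number from compound 3 to compound 4 (0.48 log units; beyond the scatter) and nothing else in the molecule differs. For the compounds shown here, the new compound does not stand apart from the rest of the series, however, with a 1.0-fold higher number from compound 2 to compound 4 (0.01 log units; within the scatter) and a 1.9-fold higher number from compound 1 to compound 4 (0.29 log units; within the scatter), so among the pairs involving compound 4, only the pair with compound 3 shows a difference beyond the scatter. Nothing available explains this step.

Going by these compounds, it remains open how a methyl, a longer alkyl chain, an amine or a carboxylic acid on this same aromatic carbon would read out. Such groups would show whether ethyl and trifluoromethyl mark two ends of a trend or are just two isolated points.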